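The source may report more compounds than this note shows. Statements on the series, on what has been measured and on what is new or still open speak of the compounds shown alone.

Of the compounds shown here, three built on a shared core have so far been measured in a functional assay on HepG2 cells (Homo sapiens) for antiproliferative activity, read by MTT assay, with a stated time of 72 h; on this read-out lower numbers stand for stronger inhibition and higher numbers for weaker inhibition. Within the data shown here, compound 2 `CCCCc1cn(C[C@H](O)[C@H]2OC(=O)C(OCc3ccccc3)=C2OCc2ccccc2)nn1` is the only one that returns a number: in this assay compound 2 gives 32800 nM. Compound 1 `Cc1ccc(-c2cn(C/C=C3\OC(=O)C(OCc4ccccc4)=C3OCc3ccccc3)nn2)cc1` reaches only a limit of the assay, and in this assay compound 1 gives > 100000 nM. Compound 3 `COc1ccccc1-c1cn(C/C=C2\OC(=O)C(OCc3ccccc3)=C2OCc2ccccc2)nn1` likewise sits at a limit, and in this assay compound 3 gives > 100000 nM. Among the measured compounds shown here, the single step between measured compounds, a step that the two limits leave unreadable from compound 1 to compound 3, runs between two values at the limit of > 100000 nM in this assay, at which 2 of the 3 values shown sit, and is therefore unreadable; it also concerns a different part of the molecule than the change considered here.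

Compound 4 `C[Si](C)(C)c1cn(C[C@H](O)[C@H]2OC(=O)C(OCc3ccccc3)=C2OCc2ccccc2)nn1` is not yet measured. It differs from compound 2 in one place: a group of 4 heavy atoms (3 carbon, 1 silicon; no ring) in place of a group of 4 heavy atoms (4 carbon; no ring), on an aromatic carbon. For the measured compounds named here, no measured step involves this kind of exchange, so nothing among the measured compounds says in which direction the number should move. Going by the values given here, the account therefore rests on compound 2 alone, whose value of 32800 nM is the only number in this assay. Compound 4 is expected to stay close to it, with a step of a 1.1-fold lower number from compound 2 to compound 4 (0.04 log units; within the scatter) that is not expected to exceed the scatter. The estimate for compound 4 is 30000 nM, within 8000 nM to 100000 nM, with a fair chance that the assay reports only a limit.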

Compound 4, half-maximal inhibitory concentration: 24100 nM
Estimate against measurement, compound 4: 1.2-fold (0.10 log units) above; measured number inside the range.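

In this assay, the exchange of butyl for the group of 4 heavy atoms (3 carbon, 1 silicon) gives a 1.4-fold lower number from compound 2 to compound 4 (0.13 log units; within the scatter), so the two values cannot be placed in any order. Among these compounds, this is the first readable step at this position, an aromatic carbon of the five-membered aromatic ring with 3 nitrogen, and it shows that this silicon-bearing group can take the place of butyl, with the same count of heavy atoms, without a shift beyond the usual scatter. Compound 2 and compound 4 both return a number rather than a limit, so this position now has two readable values, and they stand level.

From the compounds shown here alone, whether that holds for other groups at this position, such as a longer chain, an amine or a carboxylic acid, stays open, since one step within the scatter says nothing about groups of a different size or kind. The step from compound 1 to compound 3 also remains unreadable, and it gives no size for the change it concerns: the limit of > 100000 nM in this assay, at which 2 of the 4 values shown sit.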